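A few compounds are considered here, and "the series" means these few. Any claim that something is new, unique, unknown or untested is made for them only; others in the source may bear on it.

Going by the values given here, compound 1 `N#CC1=C(N)Oc2c(c3nc4ccccc4nc3c3ccccc23)C12C(=O)N(Cc1cnnn1-c1ccc(N)cc1)c1ccccc12` and compound 2 `Cc1cccc(-n2nncc2CN2C(=O)C3(C(C#N)=C(N)Oc4c(N)cc5nc6ccccc6nc5c43)c3ccccc32)c1` share the same core but differ from each other in more than one place, so no single step between them is counted. In a functional assay on HepG2 cells (Homo sapiens) for antiproliferative activity, read by MTT assay, with a stated time of 48 h (on this read-out lower numbers stand for stronger inhibition and higher numbers for weaker inhibition), compound 1 gives only a limit, > 50000 nM. In this assay compound 2 likewise gives only a limit, > 50000 nM. Among the compounds with values here, both values sit at the limit of > 50000 nM in this assay, at which 2 of the 2 values shown sit, so compound 2 stands at the same limit as the only other measured compound, and no ordering of the two can be drawn. Compound 3 `N#CC1=C(N)Oc2c(N)cc3nc4ccccc4nc3c2C12C(=O)N(Cc1cnnn1-c1ccccc1Br)c1ccccc12` differs from compound 2 in one place: 2-bromophenyl in place of 3-methylphenyl on an aromatic nitrogen. Within the data shown here, with no measured step to lean on, the expected change is none beyond the scatter: a step that the limit leaves unreadable from compound 2 to compound 3. In this assay compound 3 is accordingly expected to give about 60000 nM, within a range from 20000 nM to 200000 nM, and most probably reported again only as a limit rather than as a number.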

Compound 3, half-maximal inhibitory concentration: 38000 nM
Compound 3: the middle estimate sits 1.6-fold (0.20 log units) above what was measured; measured number inside the range.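

In this assay, going by these compounds alone, compound 3 gives the first reading in this set that is a number rather than a limit, so this position on the triazole nitrogen can carry a group that brings a value into the measurable range. Placing 2-bromophenyl there in place of 3-methylphenyl gives an at least 1.3-fold lower number from compound 2 to compound 3 (0.11 log units; that floor lies within the scatter), a step with a floor but no true size, and that floor cannot support a claim of gain. Compound 3 is also the only one of the three compounds shown that does not sit at the limit: the limit of > 50000 nM in this assay, at which 2 of the 3 values shown sit.

As far as these compounds go, the true size of the step stays open, as does whether the bromine itself or the loss of the methyl group matters. An unsubstituted phenyl, or chlorine in place of the bromine, would speak to that question.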